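This account rests on a few compounds, and the source may have more. Where it says the series, first, only, none or still open, it means among the compounds named here.

Values in an ADME assay on Vero cells (Chlorocebus sabaeus) for cytotoxicity, with a stated time of 7 days; on this read-out lower numbers stand for higher toxicity in this test and higher numbers for lower toxicity in this test:
- compound 1 `COc1ccc2[nH]c(C(=O)N3CC(=O)N(Cc4ccccc4)[C@@H](CN4CCC5(CC4)CC5)C3)cc2c1`: 17100 nM
- compound 2 `COc1ccc2[nH]c(C(=O)N3CC(=O)N(Cc4ccccc4)[C@@H](COC(C)(C)C)C3)cc2c1`: 78200 nM
- compound 3 `COc1ccc2[nH]c(C(=O)N3CC(=O)N(Cc4ccccc4)[C@@H](CN4CCN(c5ccc(F)cc5)CC4)C3)cc2c1`: > 30000 nM (a limit)

Compound 2 stands highest of the two values in this assay that are numbers. Among the compounds with values here, the value for compound 3 is a limit of the assay and gives no measured step.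

Compound 4 `COc1ccc2[nH]c(C(=O)N3CC(=O)N(Cc4ccccc4)[C@@H](CN4CCC(C(C)C)CC4)C3)cc2c1` is the next case. The change is 4-isopropylpiperidin-1-yl in place of tert-butoxy on a saturated chain carbon bound to a saturated ring carbon, on a saturated chain carbon bound to a saturated ring carbon. Cut one bond further out, it reads (tert-butoxy)methyl to (4-isopropylpiperidin-1-yl)methyl.

Within the data shown here, the one measured step that bears on this is a 4.6-fold higher number from compound 1 to compound 2 (0.66 log units; beyond the scatter), where tert-butoxy also takes the place of a group with a six-membered non-aromatic ring with 1 hetero atom. The change to compound 4 runs the other way, so a modest move to a lower number, beyond the scatter, is expected. Compound 3 also has a ring-bearing group at this place and goes against a simple pattern, so the range is kept wide, and the upper end reaches past its limit. The expected step is a 4.3-fold lower number from compound 2 to compound 4 (0.64 log units; beyond the scatter). For compound 4 the estimated value is 18000 nM, with an expected range of 8000 nM to 45000 nM.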

Compound 4, half-maximal cytotoxic concentration: 3800 nM
The estimate for compound 4 lay 4.7-fold (0.68 log units) above the measured number; measured number outside the range, below it.
By their numbers in this assay, from the lowest: compound 4; then compound 1; then compound 2.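

Replacing tert-butoxy with 4-isopropylpiperidin-1-yl on this saturated chain carbon gives a 21-fold lower number from compound 2 to compound 4 (1.31 log units; beyond the scatter) in this assay, so this place can move the number much further than the first measured step showed. The two groups that carry a six-membered non-aromatic ring with 1 hetero atom are also not interchangeable, with a 4.5-fold lower number from compound 1 to compound 4 (0.65 log units; beyond the scatter) and compound 4 now holding the lowest of the three numbers. Compound 3 also bears a ring at this place and has > 30000 nM as a limit of the assay, so it goes against any rule that ring-bearing groups here lower the number.

Still open, on these data alone, is how far the ring and the isopropyl each contribute, which unsubstituted piperidin-1-yl would help separate, and how a small open-chain amine such as dimethylamino or a carboxylic acid at this place would read in this assay. Nothing given here accounts for the size of these steps.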